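Tert-butyl in place of cyclopropyl: compound 3 to compound 4

The source may hold more compounds than are shown below. What is called first, only, known or untested is meant among the compounds shown, and "the series" means these compounds.

In a toxicity assay on microsomes from liver (Homo sapiens) for metabolic stability, read by LC-MS, using NADPH, tested at 1 uM (a lower number here means slower removal, a higher number faster removal of the compound), compound 3 (`Cc1nc(C)n(CC(=O)N2CCN(c3sc(C(F)(F)F)nc3-c3cnc(C4CC4)nc3)C[C@H]2C)n1`) gives only a limit (< 10 mL.min-1.g-1). Compound 1 (`CCOc1ncc(-c2nc(C(F)(F)F)sc2N2CCN(C(=O)Cn3nc(C)nc3C)[C@H](C)C2)cn1`) also gives only a limit (< 10 mL.min-1.g-1). Compound 2 (`Cc1ncc(-c2nc(C(F)(F)F)sc2N2CCN(C(=O)Cn3nc(C)nc3C)[C@H](C)C2)cn1`) gives a limit too (< 10 mL.min-1.g-1). All three readings rest at the same limit (the limit of < 10 mL.min-1.g-1 in this assay, at which 3 of the 3 values shown sit), so compound 3 has no number of its own.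

Compound 4 (`Cc1nc(C)n(CC(=O)N2CCN(c3sc(C(F)(F)F)nc3-c3cnc(C(C)(C)C)nc3)C[C@H]2C)n1`) carries tert-butyl in place of cyclopropyl on an aromatic carbon, between two ring nitrogen atoms and para to a large group (tert-butyl in place of cyclopropyl on an aromatic carbon). Three measured steps exchange the group on an aromatic carbon: (a step that the two limits leave unreadable from compound 2 to compound 3), (a step that the two limits leave unreadable from compound 1 to compound 3) and (a step that the two limits leave unreadable from compound 1 to compound 2). None of them has a readable size, so none offers a size or direction to carry over. No step beyond the usual scatter is therefore expected in this assay, and the expected step is small (a number no lower from compound 3 to compound 4 (the limit leaves the size open)). Compound 4 may well report only a limit as well. For compound 4 the estimated value is near the limit (10 mL.min-1.g-1), with an expected range from 5 mL.min-1.g-1 to 22 mL.min-1.g-1 as the outer ends.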

Compound 4, intrinsic clearance in microsomes: 449 mL.min-1.g-1
Compound 4: the middle estimate sits 45-fold (1.65 log units) below what was measured; measured number above the stated range.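

In this assay, the group on the aromatic carbon between two ring nitrogen atoms proves able to change the read-out strongly: tert-butyl gives an at least 44-fold higher number from compound 3 to compound 4 (1.65 log units; beyond the scatter), and the same exchange against the other two groups gives an at least 44-fold higher number from compound 2 to compound 4 (1.65 log units; beyond the scatter) and an at least 44-fold higher number from compound 1 to compound 4 (1.65 log units; beyond the scatter). The steps among compound 1, compound 2 and compound 3 cannot be read, so the apparent flatness of this position among methyl, ethoxy and cyclopropyl reaches only as far as the shared limit: the limit of < 10 mL.min-1.g-1 in this assay, at which 3 of the 4 values shown sit. Among the four groups shown, only tert-butyl lifts the value clear of that limit.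

From the compounds shown here alone, how an isopropyl or a 1-methylcyclopropyl group on this carbon would read remains open, so the point along this series at which intrinsic clearance begins to climb is not fixed. Any differences among compound 1, compound 2 and compound 3 beneath the limit also remain unknown.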